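The source may hold more compounds than are shown below. What is called first, only, known or untested is meant among the compounds shown, and "the series" means these compounds.

Of the compounds shown here, three sharing one core have been measured in an assay on isolated protein for displacement of a labelled ligand from Orexin/Hypocretin receptor type 1 (Homo sapiens), with a stated time of 90 min; on this read-out lower numbers stand for stronger inhibition and higher numbers for weaker inhibition. Compound 1 `COc1ccc(N2C(=O)N(Cc3ccc(F)cc3Cl)c3ccccc3S2(=O)=O)cc1OC` reaches only a limit of the assay in this assay, namely > 2510 nM. Compound 2 `COc1ccc(N2C(=O)N(Cc3c(F)cc(F)cc3Cl)c3ccccc3S2(=O)=O)cc1OC` gives 25.1 nM in this assay, and compound 3 `COc1ccc(N2C(=O)N(Cc3c(F)cc(C)cc3Cl)c3ccccc3S2(=O)=O)cc1OC` gives 6.31 nM. The move an at least 100-fold lower number from compound 1 to compound 2 (2.00 log units; beyond the scatter) and the move an at least 390-fold lower number from compound 1 to compound 3 (2.59 log units; beyond the scatter) both set out from the limit (the limit of > 2510 nM in this assay, at which 1 of the 3 values shown sits), while the move a 4.0-fold lower number from compound 2 to compound 3 (0.60 log units; beyond the scatter) is modest. Among the numbers shown, compound 3 holds the lowest, with compound 2 the nearest to it.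

Compound 4 `COc1ccc(N2C(=O)N(Cc3c(F)cc(F)cc3OC)c3ccccc3S2(=O)=O)cc1OC` differs from compound 3 by 2,4-difluoro-6-methoxyphenyl in place of 2-chloro-6-fluoro-4-methylphenyl on a saturated chain carbon bound to an amide-type nitrogen in a ring. The measured moves bear on this change only in part: the exchange of methyl for fluoro runs back along the move a 4.0-fold lower number from compound 2 to compound 3 (0.60 log units; beyond the scatter), whereas the exchange of chloro for methoxy has no measured counterpart among these compounds. A return toward the value of compound 2 is therefore expected, with added uncertainty from the untested exchange, and the step from compound 3 is estimated as a 6.3-fold higher number from compound 3 to compound 4 (0.80 log units; beyond the scatter). Compound 4 is expected to give about 40 nM in this assay, within a range from 10 nM to 160 nM.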

Compound 4, inhibition constant: 63.1 nM
For compound 4 the middle estimate is 1.6-fold (0.20 log units) below the measured one; the range from low to high includes it.
By their numbers in this assay, from the lowest: compound 3; then compound 2; then compound 4. At a limit, above all of these: compound 1.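

Methoxy in place of chloro on an aromatic carbon, an exchange without a measured counterpart until now, gives in this assay a 2.5-fold higher number from compound 2 to compound 4 (0.40 log units; beyond the scatter), so this exchange raises the number on the ring that carries two fluoro groups. The whole change of 2-chloro-6-fluoro-4-methylphenyl to 2,4-difluoro-6-methoxyphenyl on a saturated chain carbon bound to an amide-type nitrogen in a ring gives a 10-fold higher number from compound 3 to compound 4 (1.00 log units; beyond the scatter), which leaves compound 3 with the lowest number of the four and shows that this position tolerates a group with a hydrogen-bond acceptor at a modest cost. The step of an at least 39-fold lower number from compound 1 to compound 4 (1.59 log units; beyond the scatter) sets out from compound 1, whose value is a limit of the assay and not a number: the limit of > 2510 nM in this assay, at which 1 of the 4 values shown sits.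

The compounds shown leave open how methoxy in place of chloro behaves on a ring that also carries methyl, and whether ethoxy or a dimethylamino group in place of methoxy would lower the number or raise it further. Going by these compounds, the shared core is the same in all four compounds, so the effect of a nitrile or a carboxylic acid placed on it also stays open.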